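Adding a Methoxy Group to Compound 1

The compounds below may be only part of what the source reports. "The series", "measured", "known", "first", "only" and "open" are said of these compounds alone.

Compound 1 `CCN1CCN(c2cc(C)c3cc(NC(=O)c4ccccc4)ccc3n2)CC1` gives 14200 nM.
Compound 2 `Cc1cc(NCCN2CCCC2)nc2ccc(NC(=O)c3ccc(Cl)c(Cl)c3)cc12` gives 1280 nM.
Compound 3 `Cc1cc(NCCN2CCCCC2)nc2ccc(NC(=O)c3ccc(Cl)c(Cl)c3)cc12` gives 1190 nM.

These three compounds have been tested in a functional assay on MCF7 cells (Homo sapiens) for antiproliferative activity, read by MTT assay, with a stated time of 72 h; a higher number here means a weaker inhibitor, a lower number a stronger inhibitor. Compound 1 gives the highest number of the three; compound 2 and compound 3 both give lower numbers, and both gaps lie beyond the scatter. Compound 4 `CCN1CCN(c2cc(C)c3cc(NC(=O)c4ccc(OC)cc4)ccc3n2)CC1` differs from compound 1 in one place: methoxy in place of hydrogen on an aromatic carbon. Among the compounds with values here, the only measured step, a 1.1-fold lower number from compound 2 to compound 3 (0.03 log units; within the scatter), swaps piperidin-1-yl for pyrrolidin-1-yl and so says nothing about a methoxy on the aromatic ring; compound 2 and compound 3 differ from compound 1 in more than one place. Within the data shown here, no measured step bears on this change. The expected step is therefore none beyond the scatter, a 1.2-fold lower number from compound 1 to compound 4 (0.07 log units; within the scatter). Compound 4 is estimated at 12000 nM, within 5000 nM to 30000 nM.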

Compound 4, half-maximal inhibitory concentration: 7690 nM
For compound 4 the middle estimate is 1.6-fold (0.19 log units) above the measured one, within the range that was stated.
By their numbers in this assay, from the lowest: compounds 3 and 2 (each within the scatter of the next); then compounds 4 and 1 (each within the scatter of the next).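

In this assay, methoxy in place of hydrogen, which turns benzoyl into (4-methoxyphenyl)carbonyl, gives a 1.8-fold lower number from compound 1 to compound 4 (0.27 log units; within the scatter) and so leaves the number within the scatter. Within the data shown here, this is the first direct reading at this position, and it shows that the ring carbon para to a large group accepts a methoxy with no clear change in the number. Nothing measured here offers an explanation for this result.

On these data alone, whether an amine, a carboxylic acid or a longer chain such as ethoxy at this position would move the number beyond the scatter stays open. Also open, as far as these compounds go, is whether methoxy would give a similar step alongside the side chain of compound 2 or compound 3.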